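A Bromine on the Fused Ring of Compound 1

A few compounds are considered here, and "the series" means these few. Any claim that something is new, unique, unknown or untested is made for them only; others in the source may bear on it.

Compound 1 `NN1C(=O)/C(=C/c2c[nH]c3ccccc23)SC1=S` is the reference point. For the measured compounds named here, in a functional assay on HL-60 cells (Homo sapiens) for cytotoxicity, read by MTT assay, with a stated time of 72 h (a higher number here means a weaker inhibitor, a lower number a stronger inhibitor), compound 1 gives 3610 nM, the only measured number among the two compounds in hand; the other value is the limit of > 50000 nM in this assay, at which 1 of the 2 values shown sits. Compound 2 `O=C1NC(=S)S/C1=C\c1c[nH]c2ccccc12` carries hydrogen in place of amino on an amide-type nitrogen in a ring. In this assay compound 2 reaches only a limit of the assay, > 50000 nM. The resulting step, an at least 13-fold higher number from compound 1 to compound 2 (1.14 log units; beyond the scatter), shows how much the amino group on that ring nitrogen matters.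

Compound 3 `NN1C(=O)/C(=C/c2c[nH]c3ccc(Br)cc23)SC1=S` keeps that amino group and differs from compound 1 by bromo in place of hydrogen on an aromatic carbon. Going by the values given here, no measured step touches this position; the single measured step concerns the ring nitrogen and fixes only the starting point. A change in this assay of no more than the usual scatter is therefore expected. Compound 3 is estimated at 2500 nM, within 800 nM to 8000 nM. The expected step is a 1.4-fold lower number from compound 1 to compound 3 (0.16 log units; within the scatter).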

Compound 3, half-maximal inhibitory concentration: 6740 nM
The estimate for compound 3 lay 2.7-fold (0.43 log units) below the measured number; the measured number falls inside the stated range.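

The bromo group on this aromatic carbon, para to a fused ring, is the first change shown on this part of the core, and in this assay it gives a 1.9-fold higher number from compound 1 to compound 3 (0.27 log units; within the scatter). This step stays within the scatter, so compound 1 and compound 3 cannot be told apart here, whereas the step at the ring nitrogen, an at least 13-fold higher number from compound 1 to compound 2 (1.14 log units; beyond the scatter), lies beyond it and remains the only change shown that clearly separates two compounds. Nothing measured here bears on why the bromo group leaves the number within the scatter.

Going by these compounds, whether a methoxy group, a carboxylic acid or an amine on this same carbon would also stay within the scatter remains open. So does whether a methylamino or acetylamino group on the ring nitrogen would keep the activity that the amino group gives.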